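Notes on compound 4: pyrazin-2-yl for pyridin-3-yl

The compounds below may be only part of what the source reports. "The series", "measured", "known", "first", "only" and "open" are said of these compounds alone.

Measured so far:
compound 1 `Nc1ccccc1NC(=O)c1ccc(CSC(=S)N2CCN(c3cccnc3)CC2)cc1` — 27.6%
compound 2 `Nc1ccccc1NC(=O)c1ccc(CSC(=S)N2CCc3cc(Cl)ccc32)cc1` — 57.7%
compound 3 `Nc1ccccc1NC(=O)c1ccc(CSC(=S)N2CCc3cc([N+](=O)[O-])ccc32)cc1` — 26.8%

In a functional assay on MGC-803 cells (Homo sapiens) for antiproliferative activity, read by CCK-8 assay, with a stated time of 72 h, tested at 2 uM (on this read-out lower numbers stand for a weaker effect and higher numbers for a stronger effect at the one concentration tested), compound 1 gives 27.6%, the second highest of the three numbers. Compound 3 sits within the scatter of compound 1, so no order between those two can be read. For the measured compounds named here, compound 2 stands apart: the only single-place step recorded in this set is a number 30.9 percentage points lower from compound 2 to compound 3 (beyond the scatter), and compound 2 lies a comparable distance above compound 1.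

Compound 4 `Nc1ccccc1NC(=O)c1ccc(CSC(=S)N2CCN(c3cnccn3)CC2)cc1` is the next step from compound 1. The change is pyrazin-2-yl in place of pyridin-3-yl on an amine nitrogen in a ring. Going by the values given here, the one measured step, nitro in place of chloro on an aromatic carbon of the shared core, concerns a different place and a different kind of group, so it does not bear on this change. Among the compounds with values here, no measured step covers an exchange on the amine nitrogen in a ring. With nothing pointing either way, the expectation for this assay is a step within the scatter, and the estimated step is a number 0.6 percentage points lower from compound 1 to compound 4 (within the scatter).

Compound 4 is therefore estimated at 27%, with a range from 14% to 40%.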

Compound 4, a percentage reported as inhibition, at one concentration (the size of the read-out at that concentration, not a potency): 27.1%
Compound 4: middle estimate off by 0.1 percentage points, on the low side; the measured number falls inside the stated range.
By their numbers in this assay, from the lowest: compounds 3, 4 and 1 (each within the scatter of the next); then compound 2.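

For the compounds shown here, on an amine nitrogen in a ring, pyrazin-2-yl in place of pyridin-3-yl gives a number 0.5 percentage points lower from compound 1 to compound 4 (within the scatter) in this assay and is the first exchange recorded at this position. For this one pair, the second ring nitrogen of the pyrazin-2-yl group comes with no step beyond the scatter, so the read-out does not separate these two six-membered aromatic rings. No measurement on hand bears on this result.

Going by these compounds, it remains open whether this position can move the number at all, since both groups are six-membered aromatic rings containing nitrogen. A plain phenyl ring, a methyl group or an acetyl group on the same amine nitrogen would test this, and a single pair says nothing about those groups.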